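Sulfonyl substituent change on a benzothiazole amide series

This account rests on a few compounds, and the source may have more. Where it says the series, first, only, none or still open, it means among the compounds named here.

Measured compounds:
compound 1 `COc1c(NS(=O)(=O)C2CC2)cc(-c2ccc3nc(NC(=O)C4CC4)sc3c2)cc1C(N)=O` — "not determined" (no result reported)
compound 2 `COc1c(NS(=O)(=O)c2ccc(F)cc2)cc(-c2ccc3nc(NC(=O)C4CC4)sc3n2)cc1C(N)=O` — 22100 nM

Compound 1 carries a cyclopropylsulfonyl group, but in a functional assay on MCF7 cells (Homo sapiens) for antiproliferative activity, read by MTT assay, with a stated time of 72 h (on this read-out lower numbers stand for stronger inhibition and higher numbers for weaker inhibition), compound 1 gives "not determined" (no result reported), so it stands nowhere on the scale shown. Among the measured compounds shown here, the only measured reference is compound 2, which in this assay gives 22100 nM and shares the (4-fluorophenyl)sulfonyl group but differs from compound 3 in the core. Compound 3 `COc1c(NS(=O)(=O)c2ccc(F)cc2)cc(-c2ccc3nc(NC(=O)C4CC4)sc3c2)cc1C(N)=O` arises from compound 1 by the change (4-fluorophenyl in place of cyclopropyl on a sulfonyl sulfur), that is 4-fluorophenyl in place of cyclopropyl on a sulfonyl sulfur. With no measured anchor for compound 1, the size and direction of this step in this assay cannot be judged from the numbers; the expectation for compound 3 therefore rests on compound 2 alone. Compound 3 is estimated at 8000 nM, within a range of 1500 nM to 40000 nM.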

Compound 3, half-maximal inhibitory concentration: 1580 nM
Beside the measured number, compound 3's estimate is 5.1-fold (0.70 log units) above it; the measured number falls inside the stated range.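

In this assay, among the compounds shown here, compound 1 gives "not determined" (no result reported), so no step from compound 1 to compound 3 can be read. The compounds shown leave open what 4-fluorophenyl in place of cyclopropyl does to this read-out. No supporting data bear on compound 3's result.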